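The source may report more compounds than this note shows. Statements on the series, on what has been measured and on what is new or still open speak of the compounds shown alone.

Four compounds were tested in a functional assay on the whole organism for inhibition, with Rattus norvegicus as the target, read by paw edema, with a stated time of 4 h, at a dose of 50 mg/kg; on this read-out higher numbers stand for more inhibition at the one dose given (going by the name of the read-out) and lower numbers for less inhibition. Compound 1, `CC(=O)c1c(NNc2ccc(C)cc2)cc(C)oc1=O`, and compound 2, `CC(=O)c1c(NNc2ccc(Cl)cc2)cc(C)oc1=O`, share one core, while compound 3, `Cc1ccc(-n2nc3cc(C)oc(=O)c3c2C)cc1`, and compound 4, `Cc1cc2nn(-c3ccc(Cl)cc3)c(C)c2c(=O)o1`, share another; the difference between the two cores is not broken down here.

In this assay compound 1 gives 50%. Compound 2 differs from compound 1 in one place, (chloro in place of methyl on an aromatic carbon), and in this assay compound 2 gives 28.4%. That single change produced a step of a number 21.6 percentage points lower from compound 1 to compound 2 (beyond the scatter). In this assay, going by the values given here, compound 3 gives 41.7%, a number within the usual scatter of the one for compound 1 and higher than the one for compound 2.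

Compound 4 has not yet been measured in this assay. It differs from compound 3 by chloro in place of methyl on an aromatic carbon, the same change, at the same place on the ring, that separates compound 1 from compound 2. Among the compounds with values here, since only one earlier example of this change exists, and it was made on a different core, the size of the coming step is uncertain. Because a number 21.6 percentage points lower from compound 1 to compound 2 (beyond the scatter) was seen for this change on the first core, a step in the same direction is expected on the second core as well. For compound 4 the expected step is a number 17.7 percentage points lower from compound 3 to compound 4 (beyond the scatter). Compound 4 is therefore estimated at 24%, most likely between 10% and 40%.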

Compound 4, a percentage reported as inhibition, in the whole organism at one dose (the size of the read-out at that dose, not a potency): 38.2%
Compound 4: the middle estimate sits 14.2 percentage points below what was measured, within the range that was stated.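

In this assay, the swap of methyl for chloro on the aromatic ring did not repeat on the second core what it had done on the core of compound 1: here it gave a number 3.5 percentage points lower from compound 3 to compound 4 (within the scatter). Set side by side, the two steps differ by more than repeated measurements would normally scatter, so in this series the size of this step changes with the core that carries it: the same change on two cores in this assay, a number 21.6 percentage points lower (beyond the scatter) from compound 1 to compound 2 and a number 3.5 percentage points lower (within the scatter) from compound 3 to compound 4, 18.1 percentage points apart, beyond the scatter of two such steps This shows that a step seen on one core cannot simply be copied onto the other here, but it rests on a single pair of cores at a single dose, and it does not show why the two steps differ or what the same swap would do on any further core.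

The compounds shown carry only methyl or chloro at this place on the ring, so it stays open how a fluoro group, a methoxy group or an amine there would read out on either core. Going by these compounds, each core also appears with just these two groups, and the read-out gives the size of the effect at one dose rather than a potency, so it remains open whether the same picture would hold at other doses.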